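The source may hold more compounds than are shown below. What is called first, only, known or untested is meant among the compounds shown, and "the series" means these compounds.

Compound 3 `COc1ccc(-c2nc(C(=O)N3CCOCC3)sc2-c2ccc(OC)cc2)cc1` carries a morpholin-4-yl group on a carbonyl carbon. In a functional assay (aorta) with Rattus norvegicus as the target (on this read-out lower numbers stand for an effect already at smaller amounts and higher numbers for an effect only at larger amounts of compound), compound 3 is known only as a limit, < 100 uM. Two relatives sharing its core do give numbers: compound 1 `C/N=C(/NC)Nc1nc(-c2ccc(OC)cc2)c(-c2ccc(OC)cc2)s1` reads 2.4 uM and compound 2 `COc1ccc(-c2nc(CNC(C)=O)sc2-c2ccc(OC)cc2)cc1` reads 8.1 uM.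

The change followed here leads to compound 4 `COc1ccc(-c2nc(C(=O)N3CCNC(CCO)C3)sc2-c2ccc(OC)cc2)cc1`: 3-(2-hydroxyethyl)piperazin-1-yl in place of morpholin-4-yl on a carbonyl carbon. In words, 3-(2-hydroxyethyl)piperazin-1-yl replaces morpholin-4-yl on a carbonyl carbon. Among the compounds with values here, no measured step makes this exact swap. The two steps that reach the starting compound, a step that the limit leaves unreadable from compound 1 to compound 3 and a step that the limit leaves unreadable from compound 2 to compound 3, cannot be sized. Within the data shown here, the only readable step, a 3.4-fold higher number from compound 1 to compound 2 (0.53 log units; beyond the scatter), is modest and concerns a different group.

The expectation therefore rests loosely on the readable neighbours, with compound 2 at 8.1 uM as the nearest guide, and a wide margin is needed. The expected change is a step that the limit leaves unreadable from compound 3 to compound 4, and its direction stays uncertain while one end is only a limit. For compound 4 the estimate is 12 uM, with an expected range from 2.5 uM to 60 uM.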

Compound 4, concentration for half-maximal effect: 9.5 uM
Beside the measured number, compound 4's estimate is 1.3-fold (0.10 log units) above it; the range from low to high includes it.
By their numbers in this assay, from the lowest: compound 1; then compounds 2 and 4 (each within the scatter of the next).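

Compound 3 is known only as a limit, so the change from compound 3 to compound 4 cannot be given a size: the limit of < 100 uM in this assay, at which 1 of the 4 values shown sits.
The compounds shown leave open whether, in this assay, 3-(2-hydroxyethyl)piperazin-1-yl in place of morpholin-4-yl on a carbonyl carbon raises, lowers or leaves the number unchanged.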